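Adding a heptyl group to the chain of compound 1

A few compounds are considered here, and "the series" means these few. Any claim that something is new, unique, unknown or untested is made for them only; others in the source may bear on it.

compound 1 `CCCCCC(CCO)n1cnc2c(Cl)ncnc21` gives > 50000 nM as a limit
compound 2 `CCCCCC(CCO)n1cnc2c(N)ncnc21` gives > 50000 nM as a limit
compound 3 `CCCCCC(CCO)n1cnc2cncnc21` gives > 50000 nM as a limit

In a functional assay on SW480 cells (Homo sapiens) for antiproliferative activity, read by MTT assay, with a stated time of 48 h (a lower number here means a stronger inhibitor, a higher number a weaker inhibitor), compound 1 reads > 50000 nM and this is a limit, not a number. The three compounds stand together at the limit of > 50000 nM in this assay, at which 3 of the 3 values shown sit, and cannot be ranked. The change under study is heptyl in place of hydrogen on a saturated chain carbon, six bonds along the chain from an aromatic nitrogen and it turns compound 1 into compound 4 `CCCCCCCCCCCCC(CCO)n1cnc2c(Cl)ncnc21` with the core left as it was.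

The measured steps all concern the group on the aromatic carbon, not the chain. They are a step that the two limits leave unreadable from compound 1 to compound 2 and a step that the two limits leave unreadable from compound 1 to compound 3 and a step that the two limits leave unreadable from compound 2 to compound 3 and none gives a size to carry over. Going by the values given here, no measured step touches the chain, and the expectation rests on the structural change alone. Any readable value for compound 4 would mark a stronger inhibitor than compound 1, though compound 4 may also stay at the limit. The expected result is an at least 3.3-fold lower number from compound 1 to compound 4 (0.52 log units; beyond the scatter) by this estimate. For compound 4 the estimated value is 15000 nM with an expected range from 4000 nM to 50000 nM as its bounds.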

Compound 4, half-maximal inhibitory concentration: > 50000 nM
Compound 4: a limit, no number; the forecaster's own chance of this, stated with the estimate: 35%; middle value at least 3.3-fold (0.52 log units) away from the limit.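

In this assay compound 4 gives > 50000 nM as a limit, not a number. The step from compound 1 to compound 4 therefore cannot be read, and the compounds shown cannot be ranked: the limit of > 50000 nM in this assay, at which 4 of the 4 values shown sit.
The compounds shown leave open whether any change on the chain or the aromatic carbon would give a readable value.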